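Amide Variation at the Carbonyl of Compound 2

A few compounds are considered here, and "the series" means these few. Any claim that something is new, unique, unknown or untested is made for them only; others in the source may bear on it.

Within the data shown here, compound 2 `CCn1c(C(=O)N(C)CC(=O)O)ccc1C(CC)(CC)c1ccc(OCC(O)C(C)(C)C)c(C)c1` gives 740 nM in an assay on HL-60 cells for agonist activity at vitamin D3 receptor (Homo sapiens), read by microscopy, with a stated time of 96 h (on this read-out higher numbers stand for an effect only at larger amounts of compound and lower numbers for an effect already at smaller amounts), and stands highest of the two numbers so far; compound 1 `CCn1c(C(=O)NCCN)ccc1C(CC)(CC)c1ccc(OCC(O)C(C)(C)C)c(C)c1` gives 10 nM. Compound 3 `CCn1c(C(=O)Nc2cccc(C(F)(F)F)c2)ccc1C(CC)(CC)c1ccc(OCC(O)C(C)(C)C)c(C)c1` carries (3-(trifluoromethyl)phenyl)amino in place of (carboxymethyl)(methyl)amino on a carbonyl carbon. Among the measured compounds shown here, the only step that bears on this position, a 74-fold higher number from compound 1 to compound 2 (1.87 log units; beyond the scatter), shows that a change at this carbonyl can move the number strongly. With no measured aryl amide, a step back toward compound 1 is expected but uncertain; for compound 3 the expected step is a 12-fold lower number from compound 2 to compound 3 (1.09 log units; beyond the scatter), giving an estimated 60 nM within 6 nM to 600 nM.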

Compound 3, half-maximal effective concentration: > 50000 nM
Compound 3 gave a limit, no number; the forecaster's own chance of this, stated with the estimate: 5%; at least 830-fold (2.92 log units) between middle value and limit.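

Compound 3 gave a limit of the assay and not a number: the limit of > 50000 nM in this assay, at which 1 of the 3 values shown sits. Putting (3-(trifluoromethyl)phenyl)amino on this carbonyl carbon gives an at least 67-fold higher number from compound 2 to compound 3 (1.82 log units; beyond the scatter), and the same group set against compound 1 gives an at least 5000-fold higher number from compound 1 to compound 3 (3.69 log units; beyond the scatter). An aromatic ring on the amide nitrogen therefore did not move the read-out back toward compound 1, and this change took it further away than the earlier step at this carbonyl had.

On these data alone, it remains open whether this shift belongs to the ring or to the trifluoromethyl group. As far as these compounds go, how a plain phenyl amide or a longer aminoalkyl chain would read is also open.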